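Moving the pyridine attachment on the chain carbon substituent

The compounds below may be only part of what the source reports. "The series", "measured", "known", "first", "only" and "open" are said of these compounds alone.

Compound 1 `CCCCNc1nc(N)nc2ccn(CCCc3ccccc3)c12` gives 3.78 uM in an assay on HEK293 cells for agonist activity at Toll-like receptor 8 (Homo sapiens), read by a luciferase reporter, with a stated time of 6 h; a lower number here means that less compound is needed, a higher number that more compound is needed for the effect.
Compound 2 `CCCCNc1nc(N)nc2ccn(CC=C(C)C)c12` gives > 25 uM in this assay, which is a limit of the assay rather than a number.
Compound 3 `CCCCNc1nc(N)nc2ccn(Cc3ccccn3)c12` gives > 25 uM in this assay, again a limit rather than a number.

Compound 3 therefore stands at the weak end of what has been seen: its result is the limit of > 25 uM in this assay, at which 2 of the 3 values shown sit. Compound 4 `CCCCNc1nc(N)nc2ccn(Cc3cccnc3)c12` keeps every atom of compound 3 and differs only in pyridin-3-yl in place of pyridin-2-yl on a saturated chain carbon bound to an aromatic nitrogen.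

Two measured steps lead away from compound 1 toward this region: an at least 6.6-fold higher number from compound 1 to compound 2 (0.82 log units; beyond the scatter) and an at least 6.6-fold higher number from compound 1 to compound 3 (0.82 log units; beyond the scatter), both at least modest rises in the number. The step that the two limits leave unreadable from compound 2 to compound 3 cannot be read, since both ends are limits. For the measured compounds named here, none of the measured steps moves one pyridine attachment to another, so nothing measured bears directly on the change from compound 3 to compound 4.

Compound 4 is thus expected to sit close to compound 3, with a number no higher from compound 3 to compound 4 (the limit leaves the size open) expected to be no step beyond the scatter, and most likely another limit. The estimate for compound 4 is 25 uM, ranging from 8 uM to 100 uM.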

Compound 4, minimum effective concentration: > 25 uM
Compound 4 gave a limit, no number (the forecaster's own chance of this, stated with the estimate: 60%); the middle value lies on the limit itself.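

Compound 4 also gives only a limit in this assay, so this result adds a third compound at the same boundary: the limit of > 25 uM in this assay, at which 3 of the 4 values shown sit. The steps from compound 2 and from compound 3 to compound 4 cannot be read, as both ends of each are limits, so pyridin-2-yl and pyridin-3-yl cannot be ranked, and neither gives a readable value at this position. The one readable step is an at least 6.6-fold higher number from compound 1 to compound 4 (0.82 log units; beyond the scatter), which leaves compound 1, with phenethyl on this chain carbon, as the only compound shown with an actual number.

As far as these compounds go, how far compound 2, compound 3 and compound 4 lie past the limit remains open. So does whether pyridin-4-yl, an unsubstituted phenyl or a pyridine carried on a longer chain would give a number at this position.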